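Side chain on sulfur: compound 3 to compound 4

A few compounds are considered here, and "the series" means these few. Any claim that something is new, unique, unknown or untested is made for them only; others in the source may bear on it.

Compound 3 (`CC(C)c1n[nH]c2c(NCc3ccc(-c4ccccn4)cc3)nc(SC[C@H](O)CN)nc12`) gives 63 nM in a functional assay on HT cells (Homo sapiens) for antiproliferative activity, read by fluorescence, with a stated time of 72 h (on this read-out lower numbers stand for stronger inhibition of growth and higher numbers for weaker inhibition of growth), which lies within the scatter of compound 1 (`CC(C)c1n[nH]c2c(NCc3ccc(-c4ccccn4)cc3)nc(SCCO)nc12`) at 48 nM. Compound 2 (`CC(C)c1n[nH]c2c(NCc3ccc(-c4ccccn4)cc3)nc(SCC(O)CN3CCNCC3)nc12`) gives 332 nM and is the weakest of the three.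

The next change leads to compound 4 (`CC(C)c1n[nH]c2c(NCc3ccc(-c4ccccn4)cc3)nc(SCCn3ccnc3)nc12`), with (1H-imidazol-1-yl)methyl in place of 2-amino-1-hydroxyethyl on a saturated chain carbon bound to a sulfur. The side chain thus goes from 3-amino-2-hydroxypropyl to 2-(1H-imidazol-1-yl)ethyl.

Going by the values given here, no measured compound carries an aromatic ring at this place, so the evidence is indirect. Aminomethyl on the chain gave a 1.3-fold higher number from compound 1 to compound 3 (0.12 log units; within the scatter) and no change beyond the scatter. The only ring-bearing chain, in compound 2, gave a 6.9-fold higher number from compound 1 to compound 2 (0.84 log units; beyond the scatter) and also sits apart from the aminomethyl chain, with a 5.3-fold lower number from compound 2 to compound 3 (0.72 log units; beyond the scatter) in this assay.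

Compound 4 falls between these two precedents, so a small step toward a higher number is expected, smaller than the steps seen with compound 2. The estimate amounts to an expected 1.7-fold higher number from compound 3 to compound 4 (0.24 log units; within the scatter) in this assay.

For compound 4 the expected value is 110 nM (estimated range 40 nM to 300 nM).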

Compound 4, concentration for 50% growth inhibition: 155 nM
Compound 4: the middle estimate sits 1.4-fold (0.15 log units) below what was measured; measured number inside the range.
By their numbers in this assay, from the lowest: compounds 1 and 3 (each within the scatter of the next); then compound 4; then compound 2.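

In this assay, the 2-(1H-imidazol-1-yl)ethyl chain brings the first aromatic ring to this place on sulfur, and replacing 3-amino-2-hydroxypropyl with it gives a 2.5-fold higher number from compound 3 to compound 4 (0.39 log units; beyond the scatter) as a step that the aminomethyl change on the chain did not produce. Going by these compounds alone, the same chain gives a 3.2-fold higher number from compound 1 to compound 4 (0.51 log units; beyond the scatter) with 1H-imidazol-1-yl in place of hydroxy, yet a 2.1-fold lower number from compound 2 to compound 4 (0.33 log units; beyond the scatter) with the piperazine-bearing chain replaced, so the two chains that carry a ring both read higher than compound 1 and compound 3, while the aromatic ring in compound 4 reads lower than the piperazine ring in compound 2, and no compound of the four goes against this order. Nothing measured here accounts for these steps.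

The compounds shown leave open whether the higher number of compound 4 goes with the aromatic ring itself or with the loss of the hydroxy and amino groups, as the change swaps them together. A 3-(1H-imidazol-1-yl)-2-hydroxypropyl chain, a 2-phenylethyl chain or a longer chain ending in a dimethylamine would help separate these readings.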